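A few compounds are considered here, and "the series" means these few. Any claim that something is new, unique, unknown or untested is made for them only; others in the source may bear on it.

Measured compounds:
compound 1 `COc1ccc(/C=C/c2cc(OC)cc(OC)c2/C=C/C(=O)c2ccccc2C)cc1` – 6.1 ug/mL
compound 2 `COc1ccc(/C=C/c2cc(OC)cc(OC)c2/C=C/C(=O)c2ccc(C)c(C)c2)cc1` – 1.4 ug/mL
compound 3 `COc1ccc(/C=C/c2cc(OC)cc(OC)c2/C=C/C(=O)c2ccc(C)cc2)cc1` – 5.3 ug/mL

In a functional assay on B16-F10 cells (Mus musculus) for antiproliferative activity, read by MTT assay, with a stated time of 48 h (a higher number here means a weaker inhibitor, a lower number a stronger inhibitor), compound 3 sits second highest of the three numbers: its nearest neighbour is compound 1, and the gap from compound 1 to compound 3 is a 1.2-fold lower number from compound 1 to compound 3 (0.06 log units; within the scatter); its furthest is compound 2, with a 3.8-fold higher number from compound 2 to compound 3 (0.58 log units; beyond the scatter). Compound 4 `COc1ccc(/C=C/c2cc(OC)cc(OC)c2/C=C/C(=O)c2ccc(F)cc2)cc1` is not yet measured in this assay. It differs from compound 3 by fluoro in place of methyl on an aromatic carbon.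

Among the measured compounds shown here, no measured step swaps methyl for fluoro. The closest guides are the step from compound 2 to compound 3, a 3.8-fold higher number from compound 2 to compound 3 (0.58 log units; beyond the scatter), where a methyl is lost outright, and the step from compound 1 to compound 3, a 1.2-fold lower number from compound 1 to compound 3 (0.06 log units; within the scatter), where the methyl only moves. Neither speaks directly to fluoro, a group of the same heavy-atom count. The expectation is therefore a step of a 1.1-fold lower number from compound 3 to compound 4 (0.03 log units; within the scatter), not beyond the scatter. Compound 4 is estimated at 5 ug/mL, with a range of 2 ug/mL to 12 ug/mL.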

Compound 4, half-maximal inhibitory concentration: 5.3 ug/mL
The estimate for compound 4 lay 1.1-fold (0.03 log units) below the measured number, within the range that was stated.
By their numbers in this assay, from the lowest: compound 2; then compounds 3, 4 and 1 (each within the scatter of the next).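

In this assay the change from 4-methylphenyl to 4-fluorophenyl gives no change at the digits printed from compound 3 to compound 4 (within the scatter), so at this place on the aromatic ring, fluoro and methyl cannot be told apart in this series. The 4-fluorophenyl group also stays level with the 2-methylphenyl group, with a 1.2-fold lower number from compound 1 to compound 4 (0.06 log units; within the scatter), while 3,4-dimethylphenyl remains apart, with a 3.8-fold higher number from compound 2 to compound 4 (0.58 log units; beyond the scatter); that separation now holds against all three singly substituted rings. No measurement shown bears on why these steps come out as they do.

Open, going by these compounds, is whether a methoxy group, an amine, a carboxylic acid or a longer chain at this place would also match methyl and fluoro. Also open, on these data alone, is whether the step seen with 3,4-dimethylphenyl carries over to a ring holding both fluoro and methyl.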